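Ester Oxygen Substituent Enlarged on the Dihydropyridine Core

This account rests on a few compounds, and the source may have more. Where it says the series, first, only, none or still open, it means among the compounds named here.

Compound 1 `CCO/C(O)=C1\C(C)=NC(C)=C([N+](=O)[O-])C1c1ccncc1` gives the lowest number of the three measured compounds in a functional assay (cardiac atrium) for agonist activity, with Cavia porcellus as the target (on this read-out higher numbers stand for an effect only at larger amounts of compound and lower numbers for an effect already at smaller amounts), at 6460 nM. Compound 2 `CO/C(O)=C1\C(C)=NC(C)=C([N+](=O)[O-])C1c1ccncc1` gives 48500 nM in this assay, and compound 3 `CCO/C(O)=C1\C(C)=NC(C)=C([N+](=O)[O-])C1c1ccccn1` gives 22800 nM. The step of a 7.5-fold higher number from compound 1 to compound 2 (0.88 log units; beyond the scatter) shows that shortening the chain on the oxygen weakens the effect; the step of a 3.5-fold higher number from compound 1 to compound 3 (0.55 log units; beyond the scatter) concerns the aromatic ring and does not bear on the present change.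

Compound 4 `CC1=NC(C)=C([N+](=O)[O-])C(c2ccncc2)/C1=C(\O)OC1CCCCC1` differs from compound 1 by cyclohexyl in place of ethyl on an oxygen on an unsaturated carbon. Among the measured compounds shown here, the only measured step at this place, a 7.5-fold higher number from compound 1 to compound 2 (0.88 log units; beyond the scatter), runs toward a smaller group and therefore does not show what a larger one does. Compound 1 is expected to be the closest guide, and compound 4 is estimated to give 5000 nM in this assay, within 1000 nM to 25000 nM. For the measured compounds named here, this estimate means a step of a 1.3-fold lower number from compound 1 to compound 4 (0.11 log units; within the scatter), expected to lie within or near the scatter, since no measured compound carries a ring on that oxygen.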

Compound 4, half-maximal effective concentration: 4940 nM
The estimate for compound 4 lay 1.0-fold (0.01 log units) above the measured number; low and high end bracket the measured number.
By their numbers in this assay, from the lowest: compounds 4 and 1 (each within the scatter of the next); then compound 3; then compound 2.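

In this assay the step of a 1.3-fold lower number from compound 1 to compound 4 (0.12 log units; within the scatter) stays within the scatter, so this oxygen carries a cyclohexyl ring as well as it carries ethyl, and enlarging the group from ethyl to cyclohexyl brings no measurable change. The step of a 9.8-fold lower number from compound 2 to compound 4 (0.99 log units; beyond the scatter) lies beyond the scatter, so among the three groups on this oxygen, methyl alone stands apart, with ethyl and cyclohexyl giving numbers within the scatter of each other. Nothing measured here explains this behaviour at this position.

On these data alone, it remains open whether an aromatic phenyl ring, a longer chain such as butyl or a chain ending in an amine on this oxygen would stay within the scatter of compound 1. As far as these compounds go, it is also open whether cyclohexyl in place of ethyl would read the same on compound 3, which carries pyridin-2-yl.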